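This account rests on a few compounds, and the source may have more. Where it says the series, first, only, none or still open, it means among the compounds named here.

Series notes. Two compounds carry the imidazole at the end of a saturated chain attached to the ring nitrogen of the shared core. Compound 1 `O=C1c2ccccc2C(=O)N1CCCCCCCCCCn1ccnc1` has the longer chain and no bromine; compound 2 `O=C1c2cccc(Br)c2C(=O)N1CCCCn1ccnc1` carries the bromine and the shorter chain. In a functional assay for inhibition of Thromboxane-A synthase (Rattus norvegicus) (on this read-out higher numbers stand for weaker inhibition and lower numbers for stronger inhibition), compound 1 gives 100 nM. In this assay compound 2 gives 1000 nM, the highest of the two numbers; its nearest neighbour is compound 1, whose number is lower by a gap beyond the scatter. Among the compounds with values here, the two compounds differ in both the chain and the bromine, so no single-point step is available and the gap cannot be assigned to either place.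

Compound 3 `O=C1c2cccc(Br)c2C(=O)N1CCCCCn1ccnc1` is the next candidate. Relative to compound 2 it carries (1H-imidazol-1-yl)methyl in place of 1H-imidazol-1-yl on a saturated chain carbon, four bonds along the chain from an amide-type nitrogen in a ring. The chain thereby moves one unit toward the length found in compound 1 while the bromine is kept. The step expected from compound 2 to compound 3 is a 2.2-fold lower number from compound 2 to compound 3 (0.35 log units; beyond the scatter), a lowering that is expected to reach beyond the scatter. Compound 3 is accordingly estimated at 450 nM, with a range of 150 nM to 1400 nM.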

Compound 3, half-maximal inhibitory concentration: 600 nM
The estimate for compound 3 lay 1.3-fold (0.12 log units) below the measured number; the measured number falls inside the stated range.
By their numbers in this assay, from the lowest: compound 1; then compounds 3 and 2 (each within the scatter of the next).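

Reading this assay for the first time across a single change, the step is a 1.7-fold lower number from compound 2 to compound 3 (0.22 log units; within the scatter), for (1H-imidazol-1-yl)methyl in place of 1H-imidazol-1-yl on a saturated chain carbon, four bonds along the chain from an amide-type nitrogen in a ring, with the bromine kept. This one-carbon extension of the chain therefore does not separate compound 2 and compound 3 on this read-out, so at this chain length and with the bromine present the position tolerates the change without a difference that can be told from the scatter. Nothing at hand bears on why the step is of this size.

The compounds shown leave open whether the chain has any effect of its own in this series, since a single small step cannot show how a longer chain, such as a hexyl or octyl linker carrying the same imidazole, would read with the bromine kept. They also leave open what the bromine contributes, which would take a pair differing only there, such as hydrogen or chlorine in its place on the chain of compound 3.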